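Swapping a Saturated Ring for an Aromatic One

This account rests on a few compounds, and the source may have more. Where it says the series, first, only, none or still open, it means among the compounds named here.

Compound 1 `COc1cc(N)c(Cl)cc1NC(=O)C1CCN(CC2CCCC2)CC1` is tested in a functional assay on the whole organism for antagonist activity, with Mus musculus as the target; a lower number here means that less compound is needed, a higher number that more compound is needed for the effect. There compound 1 shows only a limit, > 10 mg/kg, as the evidence notes (the limit of > 10 mg/kg in this assay, at which 1 of the 3 values shown sits). Compound 2 `COc1cc(N)c(Cl)cc1NC(=O)C1CCN(Cc2ccccc2)CC1` gives 0.5 mg/kg in this assay, and the step of an at least 20-fold lower number from compound 1 to compound 2 (1.30 log units; beyond the scatter) shows the change. Compound 3 `COc1cc(N)c(Cl)cc1NC(=O)C1CCN(Cc2ccc(OCc3ccccc3)cc2)CC1` also sits at a limit, > 4 mg/kg. The step of an at least 8.0-fold higher number from compound 2 to compound 3 (0.90 log units; beyond the scatter) points the other way. Compound 4 `COc1cc(N)c(Cl)cc1NC(=O)C1CCN(Cc2ccsc2)CC1` differs from compound 1 by thiophen-3-yl in place of cyclopentyl on a saturated chain carbon bound to an amine nitrogen in a ring. As with the phenyl of compound 2, the entering group is an aromatic ring, so the step that bears on this change is an at least 20-fold lower number from compound 1 to compound 2 (1.30 log units; beyond the scatter). A lowering of comparable size is therefore expected, an at least 12-fold lower number from compound 1 to compound 4 (1.09 log units; beyond the scatter). Compound 4 is accordingly estimated at 0.8 mg/kg, within 0.3 mg/kg to 3 mg/kg.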

Compound 4, dose for half-maximal effect: 3.4 mg/kg
Beside the measured number, compound 4's estimate is 4.3-fold (0.63 log units) below it; measured number above the stated range.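

At this place, thiophen-3-yl in place of cyclopentyl gives an at least 2.9-fold lower number from compound 1 to compound 4 (0.46 log units; beyond the scatter) in this assay, so phenyl is not the only aromatic ring that lowers the dose. Yet thiophen-3-yl in place of phenyl gives a 6.8-fold higher number from compound 2 to compound 4 (0.83 log units; beyond the scatter) and so the two aromatic rings are not interchangeable here. The first of these steps has no fixed size, as compound 1 stands at a limit: the limit of > 10 mg/kg in this assay, at which 1 of the 4 values shown sits.

Thiophen-3-yl differs from phenyl in both ring size and its sulfur atom, and the compounds shown do not separate the two. On these data alone, how a pyridyl or furanyl ring would fare at this place remains open.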